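Amide tail variation on a shared sulfonamide-benzofuranoate core

A few compounds are considered here, and "the series" means these few. Any claim that something is new, unique, unknown or untested is made for them only; others in the source may bear on it.

Measured compounds:
compound 1 `Cc1c(C(=O)OCCCN(C)C)oc2ccc(N(Cc3ccc(Br)cc3)S(=O)(=O)c3ccc(Br)cc3)cc12` — 7050 nM
compound 2 `Cc1c(C(=O)NCC(O)CO)oc2ccc(N(Cc3ccc(Br)cc3)S(=O)(=O)c3ccc(Br)cc3)cc12` — 11500 nM

Compound 1 `Cc1c(C(=O)OCCCN(C)C)oc2ccc(N(Cc3ccc(Br)cc3)S(=O)(=O)c3ccc(Br)cc3)cc12` and compound 2 `Cc1c(C(=O)NCC(O)CO)oc2ccc(N(Cc3ccc(Br)cc3)S(=O)(=O)c3ccc(Br)cc3)cc12` share one core and differ only in the tail on the carbonyl carbon. In a functional assay on HCT-116 cells (Homo sapiens) for antiproliferative activity, read by MTT assay, with a stated time of 48 h (on this read-out lower numbers stand for stronger inhibition and higher numbers for weaker inhibition), compound 1 gives 7050 nM and compound 2 gives 11500 nM. The change is a 1.6-fold higher number from compound 1 to compound 2 (0.21 log units; within the scatter). Compound 2 thus carries the higher of the two numbers, but its gap to compound 1 stays within the scatter, so no order between them is claimed.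

Compound 3 `Cc1c(C(=O)NCCNc2ccccc2)oc2ccc(N(Cc3ccc(Br)cc3)S(=O)(=O)c3ccc(Br)cc3)cc12` is not yet measured. It differs from compound 2 by anilinomethyl in place of 1,2-dihydroxyethyl on a saturated chain carbon bound to an amide-type nitrogen. No measured step covers this exchange; the only step known, from ester to amide tail, stayed within the scatter, so the tail region has so far shown little leverage on this assay. Compound 3 is therefore expected to sit near compound 2, with the step of a 1.6-fold lower number from compound 2 to compound 3 (0.22 log units; within the scatter) an estimate only. The value for compound 3 is estimated at 7000 nM, within 1500 nM to 30000 nM.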

Compound 3, half-maximal inhibitory concentration: > 40000 nM
Compound 3 ended at the assay's limit (the forecaster's own chance of this, stated with the estimate: 10%); middle value at least 5.7-fold (0.75 log units) away from the limit.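

In this assay the amide tail now shows leverage, with an at least 3.4-fold higher number from compound 2 to compound 3 (0.54 log units; beyond the scatter) when anilinomethyl takes the place of 1,2-dihydroxyethyl on a saturated chain carbon bound to an amide-type nitrogen. Set against the ester tail of compound 1, the change reads as an at least 5.6-fold higher number from compound 1 to compound 3 (0.75 log units; beyond the scatter), so the 2-anilinoethyl tail is the first change in this set to move the read-out beyond the scatter. The result for compound 3 is a limit of the assay and not a number: the limit of > 40000 nM in this assay, at which 1 of the 3 values shown sits.

How far compound 3 truly lies from the other two remains unknown, and the compounds shown do not separate the aromatic ring from the anilino nitrogen as the source of the change. A 2-phenylethyl tail, a carboxylic acid or a longer chain on the amide nitrogen would test this tail region further.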